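A few compounds are considered here, and "the series" means these few. Any claim that something is new, unique, unknown or untested is made for them only; others in the source may bear on it.

Compound 2, `O=c1cc(-c2ccccc2)oc2cc(OCCCCNc3nc4ccc(F)cc4s3)cc(O)c12`, gives 324 ug/mL in an ADME assay on MDCK cells (Canis lupus familiaris) for cytotoxicity, read by sulforhodamine B assay, with a stated time of 48 h; a lower number here means a stronger inhibitor, a higher number a weaker inhibitor. Among the measured compounds shown here, of the two numbers measured so far it carries the lower one, but the nearest, compound 1, `O=c1cc(-c2ccccc2)oc2cc(OCCCCNc3nc4ccc(Cl)cc4s3)cc(O)c12`, gives 338 ug/mL in this assay, and the gap between the two is within the scatter. Compound 3, `O=c1cc(-c2ccccc2)oc2cc(OCCCCNc3nc4c(F)cc(F)cc4s3)cc(O)c12`, differs from compound 2 by fluoro in place of hydrogen on an aromatic carbon. For the measured compounds named here, the only measured step that bears on this change is the one in which fluoro replaced chloro on an aromatic carbon, a 1.0-fold lower number from compound 1 to compound 2 (0.02 log units; within the scatter), a step that lies within the scatter. Going by the values given here, that step exchanged one halogen for another, whereas the change to compound 3 adds a second fluoro on the same fused ring; no measured step of that kind exists here. Since the halogen swap moved this assay so little, the expected step is a 1.0-fold lower number from compound 2 to compound 3 (0.01 log units; within the scatter), none beyond the scatter. Compound 3 is therefore estimated at 320 ug/mL, between 200 ug/mL and 500 ug/mL.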

Compound 3, half-maximal inhibitory concentration: 307 ug/mL
Estimate against measurement, compound 3: 1.0-fold (0.02 log units) above; low and high end bracket the measured number.
By their numbers in this assay, from the lowest: compounds 3, 2 and 1 (each within the scatter of the next).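

In this assay the addition of fluoro on the aromatic carbon ortho to a fused ring and meta to a fluoro group gives a 1.1-fold lower number from compound 2 to compound 3 (0.02 log units; within the scatter) and stays within the scatter, so this position takes a second halogen without a readable shift. The wider exchange, 4,6-difluoro-1,3-benzothiazol-2-yl in place of 6-chloro-1,3-benzothiazol-2-yl on an amine nitrogen, gives a 1.1-fold lower number from compound 1 to compound 3 (0.04 log units; within the scatter) and also stays within the scatter, so all three halogen patterns shown read alike. Nothing measured here offers a reason for this flat result.

The compounds shown carry only hydrogen, fluoro and chloro on this ring, so it stays open whether a methoxy group, an amine or a carboxylic acid at this position would move the number. They also leave open whether a longer chain between the two ring systems would do so.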